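Replacing benzamido on a saturated ring carbon

The source may report more compounds than this note shows. Statements on the series, on what has been measured and on what is new or still open speak of the compounds shown alone.

In an ADME assay on cells (Hepatocyte, Homo sapiens) for metabolic stability (on this read-out higher numbers stand for a longer-lived compound and lower numbers for a shorter-lived compound), compound 1 `O=c1cc(N2CCN(CC3CCC(NS(=O)(=O)c4ccccc4)CC3)CC2)sc2c([N+](=O)[O-])cc(C(F)(F)F)cc12` gives > 1.55 h, which is a limit. Compound 2 `O=C(NC1CCC(CN2CCN(c3cc(=O)c4cc(C(F)(F)F)cc([N+](=O)[O-])c4s3)CC2)CC1)c1ccccc1` gives > 1.55 h, which is also a limit, so it has no exact position. Among the compounds with values here, the only measured step is a step that the two limits leave unreadable from compound 1 to compound 2. The evidence amounts to the limit of > 1.55 h in this assay, at which 2 of the 2 values shown sit. Compound 3 `Cc1ccc(C(=O)OC2CCC(CN3CCN(c4cc(=O)c5cc(C(F)(F)F)cc([N+](=O)[O-])c5s4)CC3)CC2)cc1` carries ((4-methylphenyl)carbonyl)oxy in place of benzamido on a saturated ring carbon, with ((4-methylphenyl)carbonyl)oxy in place of benzamido on a saturated ring carbon. Within the data shown here, no measured step gives a size for this change, so no shift beyond the scatter is expected in this assay, in either direction. The expected change is an at least 1.0-fold lower number from compound 2 to compound 3 (0.01 log units; that floor lies within the scatter). For compound 3 the estimated half-life is 1.5 h, with an expected range of 0.6 h to 3 h.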

Compound 3, half-life: 0.148 h
The estimate for compound 3 lay 10-fold (1.01 log units) above the measured number; measured number outside the range, below it.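

In this assay the saturated ring carbon proves sensitive to the group it carries, which the first pair could not show: ((4-methylphenyl)carbonyl)oxy in place of benzamido gives an at least 10-fold lower number from compound 2 to compound 3 (1.02 log units; beyond the scatter). Against the phenylsulfonylamino compound, the same group gives an at least 10-fold lower number from compound 1 to compound 3 (1.02 log units; beyond the scatter). The step between compound 1 and compound 2 cannot be read, and both compounds remain at a limit: the limit of > 1.55 h in this assay, at which 2 of the 3 values shown sit.

The change alters both the link to the ring and the 4-methyl substituent, so their shares remain unseparated. A 4-methylbenzamido group or an unsubstituted benzoyloxy group would separate them.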